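A Chlorine Added to the Amide Phenyl Ring

The source may report more compounds than this note shows. Statements on the series, on what has been measured and on what is new or still open speak of the compounds shown alone.

Compound 1 `Cc1cc(=O)[nH]c2cc(NC(=O)c3ccccc3)ccc12` carries an amide on the shared core. Going by the values given here, in a physicochemical assay for lipophilicity (on this read-out lower numbers stand for lower lipophilicity and higher numbers for higher lipophilicity), compound 1 gives 1.66, the highest of the three numbers measured so far. The nearest to it is compound 2 `COc1ccc(C(=O)Nc2ccc3c(C)cc(=O)[nH]c3c2)cc1OC`, which in this assay gives 1.46; the gap between compound 1 and compound 2 lies within the scatter, so no order can be read from it. The furthest is compound 3 `Cc1cc(O)nc2cc(N)ccc12`, which in this assay gives 0.793, a number lower than that of compound 1 by more than the scatter allows.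

Compound 4 `Cc1cc(=O)[nH]c2cc(NC(=O)c3ccccc3Cl)ccc12` has not yet been measured in this assay. It differs from compound 1 in one place: chloro in place of hydrogen on an aromatic carbon. Among the compounds with values here, no pair of measured compounds shows this change, so its size cannot be read off directly. The writer nonetheless expects the step from compound 1 to compound 4 to be upward, beyond the scatter, by about a number 0.64 log units higher from compound 1 to compound 4 (beyond the scatter). Accordingly, for compound 4 in this assay he estimates 2.3, expecting the measured number to fall between 1.9 and 2.8.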

Compound 4, partition coefficient: 1.55
For compound 4 the middle estimate is 0.75 log units above the measured one; the measured number lies below the stated range.
By their numbers in this assay, from the lowest: compound 3; then compounds 2, 4 and 1 (each within the scatter of the next).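

Going by these compounds alone, until now no two measured compounds differed in one place, so nothing could be said about a single change on the shared core; the change from phenyl to 2-chlorophenyl now supplies the first such reading, a number 0.11 log units lower from compound 1 to compound 4 (within the scatter), in this assay. At this position, on an aromatic carbon of a six-membered aromatic ring of carbon only and ortho to a large group, chloro in place of hydrogen adds one heavy atom and yet leaves compound 1 and compound 4 in no order that this read-out can establish. Nothing available explains why the step takes this size at this position.

A single step at one position cannot show whether chloro would give a similar reading elsewhere on the same ring, so the result describes this place alone and does not extend to the ring as a whole. It also leaves open how the read-out would respond at this same position to a group of another kind, such as a carboxylic acid, an amine or a longer chain.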